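The compounds below may be only part of what the source reports. "The series", "measured", "known", "first", "only" and "open" are said of these compounds alone.

Of the compounds shown here, three have been measured in a functional assay on M14 cells (Homo sapiens) for antiproliferative activity, read by sulforhodamine B assay, with a stated time of 48 h; on this read-out lower numbers stand for stronger inhibition and higher numbers for weaker inhibition. Compound 1 `COc1cc(-c2nn(-c3ccc(NC(=O)Nc4ccc(Cl)c(C(F)(F)F)c4)cc3)cc2-c2ccncc2)ccc1Cl` gives 1740 nM. Compound 2 `COc1cc(-c2nn(-c3ccc(NC(=O)Nc4cc(C(F)(F)F)cc(C(F)(F)F)c4)cc3)cc2-c2ccncc2)ccc1Cl` gives 1990 nM. Compound 3 `O=C(Nc1ccc(-n2cc(-c3ccncc3)c(-c3ccc(Cl)c(O)c3)n2)cc1)Nc1ccc(Cl)c(C(F)(F)F)c1` gives 1430 nM. Among the measured compounds shown here, the only single-point step among them, a 1.2-fold lower number from compound 1 to compound 3 (0.09 log units; within the scatter), is within the scatter, and the three numbers lie close together, so none of them can be called stronger or weaker than another; compound 3 simply has the lowest of the three numbers, with compound 1 nearest and compound 2 furthest.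

Compound 4 `O=C(Nc1ccc(-n2cc(-c3ccncc3)c(-c3ccc(Cl)c(O)c3)n2)cc1)c1cc(Cl)cc(Cl)c1` has not yet been tested. It differs from compound 3 by 3,5-dichlorophenyl in place of (4-chloro-3-(trifluoromethyl)phenyl)amino on a carbonyl carbon, so the urea linkage of compound 3 becomes a plain amide carrying a different aromatic ring. For the measured compounds named here, no measured step touches that part of the molecule: the step from compound 1 to compound 3 changed only the oxygen substituent on the other aryl ring, and compound 2 differs from compound 1 only in the substituents of the urea-bound ring. The expectation therefore rests on the narrow spread of the three values and on the size of the change, and a moderate step towards a higher number, a 2.1-fold higher number from compound 3 to compound 4 (0.32 log units; beyond the scatter), is expected. Compound 4 is estimated at 3000 nM, with a range from 900 nM to 10000 nM.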

Compound 4, half-maximal inhibitory concentration: 1510 nM
Compound 4: the middle estimate sits 2.0-fold (0.30 log units) above what was measured; the range from low to high includes it.
By their numbers in this assay, from the lowest: compounds 3, 4, 1 and 2 (each within the scatter of the next).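

The change gives a 1.1-fold higher number from compound 3 to compound 4 (0.02 log units; within the scatter) in this assay. Among the compounds shown here, this is the first look at the carbonyl carbon: earlier steps touched only other parts of the molecule, and here the urea becomes a plain amide, losing the nitrogen and hydrogen-bond donor of (4-chloro-3-(trifluoromethyl)phenyl)amino, while 3,5-dichlorophenyl brings a differently substituted ring, without a measurable shift in this read-out. No measured information explains why the number holds steady.

The linkage and the ring substituents change together in this single step, so their separate contributions stay unresolved, and they could even offset each other. Also open, on these data alone, is how the number responds when the carbonyl carbon carries something other than an aromatic ring, such as a cyclohexyl ring, a morpholine or a short ethyl chain.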